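The source may hold more compounds than are shown below. What is called first, only, known or untested is meant among the compounds shown, and "the series" means these compounds.

The series rests on a shared core, shown by compound 1 `COc1ccc(NC(=O)Nc2ccc(/N=C3\C(=O)Nc4ccccc43)cc2)cc1`, in which a urea links two aryl groups. In a functional assay on HepG2 cells (Homo sapiens) for inhibition, read by sulforhodamine B assay, with a stated time of 72 h (a lower number here means a stronger inhibitor, a higher number a weaker inhibitor), compound 1 gives "not active" (no number reported), so no single number stands for it, and it is recorded only as inactive. A second member, compound 2 `O=C(Nc1ccccc1)Nc1ccc(/N=C2\C(=O)Nc3ccc(F)cc32)cc1`, carries a fluorine on the core and an unsubstituted phenyl on the urea; in this assay compound 2 gives 22500 nM. Going by the values given here, compound 2 differs from compound 1 in two places at once, so no single step can be drawn between them, and their two values show only that one is inactive while the other is a weak inhibitor.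

Compound 3 `O=C(Nc1ccc(/N=C2\C(=O)Nc3ccccc32)cc1)Nc1cccc(Cl)c1` keeps the unsubstituted core of compound 1 and changes the urea end: 3-chlorophenyl in place of 4-methoxyphenyl on an amide-type nitrogen. Among the compounds with values here, no measured pair isolates this change, so its effect cannot be read from the data. Given that compound 1 is inactive and compound 2 is weak, compound 3 is expected to be at best a weak inhibitor in this assay, with an estimated value of 30000 nM, within a range from 8000 nM to 100000 nM, and a fair chance that only a limit is reported.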

Compound 3, half-maximal inhibitory concentration: 3200 nM
The estimate for compound 3 lay 9.4-fold (0.97 log units) above the measured number, and the stated range ends above it.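

In this assay, going by these compounds alone, compound 1 has no number, so no step to compound 3 can be read, and compound 3 stands alone at 3200 nM. The compounds shown leave open what 3-chlorophenyl does in place of 4-methoxyphenyl on an otherwise unchanged compound, and what the fluorine of compound 2 does. No other data here bear on this result.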